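Swapping phenyl for 4-bromo-2-fluorophenyl on the shared core

The compounds below may be only part of what the source reports. "The series", "measured", "known", "first", "only" and "open" are said of these compounds alone.

Three compounds share one core and differ only in the group on the aromatic nitrogen. Compound 1 `Cn1ccc2c(Oc3ccc(NC(=O)c4nn(-c5ccc(Cl)cc5)ccc4=O)cc3)ccnc21` carries a chloro group there. In a functional assay on PC-3 cells (Homo sapiens) for cytotoxicity, read by MTT assay, with a stated time of 72 h (on this read-out higher numbers stand for weaker inhibition and lower numbers for stronger inhibition), compound 1 gives > 60000 nM, which is a limit of the assay rather than a number. Compound 2 `Cn1ccc2c(Oc3ccc(NC(=O)c4nn(-c5ccc(Br)cc5)ccc4=O)cc3)ccnc21` carries bromo and in this assay gives 23000 nM. Compound 3 `Cn1ccc2c(Oc3ccc(NC(=O)c4nn(-c5ccccc5)ccc4=O)cc3)ccnc21` carries plain phenyl and in this assay gives 58200 nM, the highest of the two numbers; its nearest neighbour is compound 2, since a 2.5-fold higher number from compound 2 to compound 3 (0.40 log units; beyond the scatter). The other step, an at least 2.6-fold lower number from compound 1 to compound 2 (0.41 log units; beyond the scatter), likewise favours bromo.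

Compound 4 `Cn1ccc2c(Oc3ccc(NC(=O)c4nn(-c5ccc(Br)cc5F)ccc4=O)cc3)ccnc21` makes the change (4-bromo-2-fluorophenyl in place of phenyl on an aromatic nitrogen). Among the compounds with values here, the bromo part of this change is covered by the step from compound 2 to compound 3; the fluoro part has no measured counterpart here. Compound 4 is therefore expected to land near compound 2, with a 2.5-fold lower number from compound 3 to compound 4 (0.40 log units; beyond the scatter). The estimate for compound 4 is 23000 nM, expected to fall between 8000 nM and 60000 nM.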

Compound 4, half-maximal inhibitory concentration: 20500 nM
The estimate for compound 4 lay 1.1-fold (0.05 log units) above the measured number, within the range that was stated.
By their numbers in this assay, from the lowest: compounds 4 and 2 (each within the scatter of the next); then compound 3. At a limit, above all of these: compound 1.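

In this assay, fluoro in place of hydrogen on an aromatic carbon gives a 1.1-fold lower number from compound 2 to compound 4 (0.05 log units; within the scatter), so the added fluoro separates these two compounds by no more than the usual scatter. The full change of phenyl to 4-bromo-2-fluorophenyl gives a 2.8-fold lower number from compound 3 to compound 4 (0.45 log units; beyond the scatter), so both bromo-bearing compounds now stand beyond the scatter from plain phenyl, and the fluoro adds nothing that this assay can resolve on top of bromo. Compound 1 stands at a limit rather than at a number, so an at least 2.9-fold lower number from compound 1 to compound 4 (0.46 log units; beyond the scatter) gives only a floor for the step from 4-chlorophenyl: the limit of > 60000 nM in this assay, at which 1 of the 4 values shown sits.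

As far as these compounds go, what fluoro does on a phenyl group without bromo remains open. So does whether an amine or a methoxy group in place of the bromo would keep, lose or improve on the number seen with bromo.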